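This account rests on a few compounds, and the source may have more. Where it says the series, first, only, none or still open, it means among the compounds named here.

Compound 1 `COc1ccc(-c2nc3ccccc3o2)cc1NC(=O)c1cc([N+](=O)[O-])ccc1Cl`: 90 nM
Compound 2 `O=C(Nc1cccc(-c2nc3ccccc3s2)c1)c1cc([N+](=O)[O-])ccc1Cl`: 580 nM
Compound 3 `O=C(Nc1ccc(Cl)c(-c2nc3ccccc3s2)c1)c1cc([N+](=O)[O-])ccc1Cl`: 410 nM

These numbers all come from a physicochemical assay for solubility, read by spectrophotometry, in phosphate buffer, measured as kinetic solubility, with a stated time of 18 h, at pH 7.4; on this read-out higher numbers stand for higher solubility and lower numbers for lower solubility. Compound 2 and compound 3 lie within the usual scatter of each other, at the upper end of the three values, while compound 1 sits clearly apart from both at the lower end.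

The compound still to be measured, compound 4 `O=C(Nc1cccc(-c2nc3ccccc3o2)c1)c1cc([N+](=O)[O-])ccc1Cl`, comes from compound 2 through a single swap: 1,3-benzoxazol-2-yl in place of 1,3-benzothiazol-2-yl on an aromatic carbon. Among the compounds with values here, no measured pair isolates this swap. Within the data shown here, the one measured step is a 1.4-fold lower number from compound 2 to compound 3 (0.15 log units; within the scatter), which is a different change, chloro in place of hydrogen on an aromatic carbon, so it is only a loose guide. It shows one small edit to compound 2 leaving the number within the scatter. The 1,3-benzoxazol-2-yl of compound 4 is also carried by compound 1, which gives 90 nM, but it differs from compound 4 elsewhere too, so that value cannot be credited to this group alone. It does tilt the expectation slightly downward, though no step beyond the scatter is expected in this assay.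

The expected change is a 1.7-fold lower number from compound 2 to compound 4 (0.22 log units; within the scatter). For compound 4 the estimated value is 350 nM, with an expected range from 110 nM to 1000 nM.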

Compound 4, solubility: 470 nM
The estimate for compound 4 lay 1.3-fold (0.13 log units) below the measured number, and the stated range covers the measured number.
By their numbers in this assay, from the lowest: compound 1; then compounds 3, 4 and 2 (each within the scatter of the next).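

In this assay, within the data shown here, putting 1,3-benzoxazol-2-yl in place of 1,3-benzothiazol-2-yl on this aromatic carbon, meta to a large group, gives a 1.2-fold lower number from compound 2 to compound 4 (0.09 log units; within the scatter) and thus stays within the usual scatter, the first pair to isolate this exchange of a ring sulfur for a ring oxygen. The low number of compound 1 therefore cannot be read as a mark of the 1,3-benzoxazol-2-yl group alone: with that group held constant, hydrogen in place of methoxy on an aromatic carbon gives a 5.2-fold higher number from compound 1 to compound 4 (0.72 log units; beyond the scatter) and so lies beyond the scatter. The data offered here contain no separate measurement that explains the size of either step.

As far as these compounds go, whether the same swap would stay within the scatter on another core, such as that of compound 3 with its chloro group, remains open, as a single pair speaks only for its own surroundings. Also open, from the compounds shown here alone, is how a different kind of group on this same aromatic carbon, such as an amine or a carboxylic acid, would compare with the two ring groups seen so far.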